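Cytotoxicity series on a fused dimedone-derived core: aryl variation

A few compounds are considered here, and "the series" means these few. Any claim that something is new, unique, unknown or untested is made for them only; others in the source may bear on it.

Measured so far:
compound 1, `COc1cc(N2C(N)=C(C#N)C(/C=C/c3ccccc3)C3=C2CC(C)(C)CC3=O)cc(OC)c1OC`: 30%
compound 2, `COc1ccccc1C1C(C#N)=C(N)N(c2cc(OC)c(OC)c(OC)c2)C2=C1C(=O)CC(C)(C)C2`: 65%

In a functional assay on Ehrlich cells (Mus musculus) for cytotoxicity, tested at 25 ug/mL (on this read-out lower numbers stand for a weaker effect and higher numbers for a stronger effect at the one concentration tested), compound 1 gives 30%, while compound 2 gives 65%. Compound 2 thus stands highest of the two numbers in this assay; its nearest neighbour is compound 1, and the gap between them, a number 35 percentage points higher from compound 1 to compound 2 (beyond the scatter), lies beyond the scatter.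

Compound 3 is `COc1cc(N2C(N)=C(C#N)C(c3ccc(O)cc3)C3=C2CC(C)(C)CC3=O)cc(OC)c1OC`. It differs from compound 2 in one place: 4-hydroxyphenyl in place of 2-methoxyphenyl on a saturated ring carbon. For the measured compounds named here, the single measured step, a number 35 percentage points higher from compound 1 to compound 2 (beyond the scatter), swaps an alkenyl-linked phenyl for a directly attached aryl ring and so bears on the present step only loosely; no measured step exchanges one aryl ring for another at this saturated ring carbon. On that basis the expected move, a number 15 percentage points lower from compound 2 to compound 3 (beyond the scatter), is small and may well stay within the scatter, with the direction uncertain. Compound 3 is therefore estimated at 50% in this assay, with a range from 25% to 75%.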

Compound 3, a percentage reported as activity, at one concentration (the size of the read-out at that concentration, not a potency): 20%
Estimate against measurement, compound 3: 30 percentage points above, and the stated range ends above it.
By their numbers in this assay, from the lowest: compounds 3 and 1 (each within the scatter of the next); then compound 2.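

In this assay, the saturated ring carbon proves sensitive to which aryl ring it carries, not merely to whether an aryl ring replaces the 2-phenylethenyl group: exchanging 2-methoxyphenyl for 4-hydroxyphenyl gives a number 45 percentage points lower from compound 2 to compound 3 (beyond the scatter), a large step between two directly attached aryl rings. A directly attached aryl ring therefore does not by itself go with the higher reading of compound 2, since 4-hydroxyphenyl in place of 2-phenylethenyl gives a number 10 percentage points lower from compound 1 to compound 3 (within the scatter), leaving compound 3 and compound 1 indistinguishable in this read-out. Nothing at hand accounts for the large step from 2-methoxyphenyl to 4-hydroxyphenyl.

This single exchange alters both the oxygen-bearing group and its place on the phenyl ring, so the compounds shown do not separate the contribution of either change. They also leave open how an unsubstituted phenyl, a pyridine ring or an aminophenyl group would read on the same saturated ring carbon, and so whether 2-methoxyphenyl is unusual among aryl groups here.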